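Ketone to hydroxamic acid at the chain end

The compounds below may be only part of what the source reports. "The series", "measured", "known", "first", "only" and "open" are said of these compounds alone.

Of the compounds shown here, three sharing one core have been measured in an assay on isolated protein for binding affinity to leukotriene B4 receptor 1 (Homo sapiens), tested at 1 uM; on this read-out lower numbers stand for less inhibition and higher numbers for more inhibition at the one concentration tested (going by the name of the read-out). Compound 1 `C=CCCCCOc1cc(O)c(C(C)=O)cc1CC=C` gives 27%, and compound 2 `C#CCCCCOc1cc(O)c(C(C)=O)cc1CC=C` gives 29%, so these two sit within the scatter of each other, as the step of a number 2 percentage points higher from compound 1 to compound 2 (within the scatter) shows. Compound 3 `C=CCc1cc(C(C)=O)c(O)cc1OCCCCCC(C)=O` gives 58% and stands highest of the three, beyond the scatter above both, with a rise of a number 31 percentage points higher from compound 1 to compound 3 (beyond the scatter) and a rise of a number 29 percentage points higher from compound 2 to compound 3 (beyond the scatter).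

Compound 4 `C=CCc1cc(C(C)=O)c(O)cc1OCCCCCC(=O)NO` carries the change (hydroxyamino in place of methyl on a carbonyl carbon). Among the measured compounds shown here, no measured step touches this same position: the two steps that exist alter the chain end one bond further in, exchanging vinyl or ethynyl for 2-oxopropyl, and both raised inhibition. They show that the end of the chain matters, but give no direction for the present exchange of methyl for hydroxyamino. The expectation therefore is for compound 4 a step of a number 3 percentage points lower from compound 3 to compound 4 (within the scatter) against compound 3, within the scatter, with a wide range. Compound 4 is estimated at 55%, between 30% and 80%.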

Compound 4, a percentage reported as inhibition, at one concentration (the size of the read-out at that concentration, not a potency): 28%
Beside the measured number, compound 4's estimate is 27 percentage points above it; the measured number lies below the stated range.
By their numbers in this assay, from the lowest: compounds 1, 4 and 2 (each within the scatter of the next); then compound 3.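

In this assay, among the compounds shown here, hydroxyamino in place of methyl on the carbonyl carbon brings a number 30 percentage points lower from compound 3 to compound 4 (beyond the scatter) and so shows, as the earlier steps could not, that this exchange at the very end of the chain does not preserve the ketone's result. The same chain end also fails to separate from the vinyl and ethynyl ends, with a number 1 percentage points higher from compound 1 to compound 4 (within the scatter) and a number 1 percentage points lower from compound 2 to compound 4 (within the scatter) placing it alongside them, which leaves the ketone of compound 3 alone above the other three. Nothing available accounts for this drop.

The compounds shown leave open whether the methyl can be exchanged at all without such a drop, which an ethyl ketone, a carboxylic acid or a primary amide at the same place would test. They also leave open how a longer chain carrying the same ketone would read.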